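The source may hold more compounds than are shown below. What is called first, only, known or untested is meant among the compounds shown, and "the series" means these compounds.

Working notes on the series. Of the compounds shown here, two have numbers so far. In a functional assay on MHCC97H cells (Homo sapiens) for antiproliferative activity, read by MTT assay, with a stated time of 48 h (on this read-out lower numbers stand for stronger inhibition and higher numbers for weaker inhibition), compound 1 `COc1cc(C(=O)/C=C/c2cn(C)c3ccccc23)cc(N)c1OC` gives 289 nM. Among the compounds with values here, compound 2 `COc1cc(C(=O)/C=C/c2c[nH]c3ccccc23)cc([N+](=O)[O-])c1OC` differs from compound 1 in two places at once, so no single step between them is stated; in this assay compound 2 gives 830 nM, the highest of the two numbers, and the gap to compound 1 lies beyond the usual scatter. Within the data shown here, what the two values show is only that the compound carrying the amino group sits at the lower number.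

Compound 3 `COc1cc(C(=O)/C=C/c2c[nH]c3ccccc23)cc(N)c1OC` is not yet measured. It is reached from compound 2 by a single change, (amino in place of nitro on an aromatic carbon). With compound 1 showing the lower number 289 nM while carrying an amino group, the expectation is that compound 3 moves toward that region rather than away from it. The expected step in this assay is a 2.4-fold lower number from compound 2 to compound 3 (0.38 log units; beyond the scatter), a moderate drop, likely beyond the scatter but not assured. For compound 3 the estimate in this assay is 350 nM, with a range from 150 nM to 850 nM.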

Compound 3, half-maximal inhibitory concentration: 263 nM
The estimate for compound 3 lay 1.3-fold (0.12 log units) above the measured number; the measured number falls inside the stated range.
By their numbers in this assay, from the lowest: compounds 3 and 1 (each within the scatter of the next); then compound 2.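

In this assay, within the data shown here, amino in place of nitro on the aromatic carbon ortho to a methoxy group gives a 3.2-fold lower number from compound 2 to compound 3 (0.50 log units; beyond the scatter), so this position now has a reading for this one change alone, which the two-place difference between the earlier compounds could not give. Hydrogen in place of methyl on the aromatic nitrogen gives a 1.1-fold lower number from compound 1 to compound 3 (0.04 log units; within the scatter), so with the amino group in place, this second change shows no difference beyond the scatter, and the gap seen earlier between the two compounds is matched by the nitro-to-amino step. No measurement here bears on why the exchange of these groups moves the number.

On these data alone, at this aromatic carbon the readings cover only nitro and amino, so it stays open whether a hydroxyl, a methylamino or an acetamido group would sit near compound 3 or near compound 2. On the aromatic nitrogen only hydrogen and methyl appear with the amino group present, which leaves open how a longer chain such as ethyl or a benzyl group would read, and whether methyl would read the same alongside nitro.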